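This account rests on a few compounds, and the source may have more. Where it says the series, first, only, none or still open, it means among the compounds named here.

Measured compounds:
Compound 1 `Cc1cc(C)c(CN2CCc3c(C)cc(O[C@@H]4CCOC4)c(Cl)c3C2=O)c(=O)[nH]1`: 61 nM
Compound 2 `Cc1cc(C)c(CN2CCc3ccc(OC(C)C)c(Cl)c3C2=O)c(=O)[nH]1`: 160 nM

In an assay on Sf9 cells for inhibition of histone-lysine N-methyltransferase EZH2 variant Y641N (Homo sapiens), read by scintillation counting, with a stated time of 60 min, in the presence of a further agent that is not named here (on this read-out lower numbers stand for stronger inhibition and higher numbers for weaker inhibition), compound 2 gives 160 nM, the higher of the two numbers; compound 1 gives 61 nM, a gap beyond the usual scatter. Compound 3 `Cc1cc(C)c(CN2CCc3ccc(O[C@@H]4CCOC4)c(Cl)c3C2=O)c(=O)[nH]1` is not yet measured. It differs from compound 2 by oxolan-3-yl in place of isopropyl on an oxygen on an aromatic ring. Compound 1 carries the same (oxolan-3-yl)oxy group and differs from compound 3 only by one further methyl on the shared core. Because compound 1 gives 61 nM, the step from compound 2 to compound 3 is expected to run toward a lower number, beyond the scatter, as a 1.8-fold lower number from compound 2 to compound 3 (0.25 log units; within the scatter). Compound 3 is estimated at 90 nM, within a range from 35 nM to 250 nM.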

Compound 3, half-maximal inhibitory concentration in the histone-lysine N-methyltransferase EZH2 assay: 110 nM
The estimate for compound 3 lay 1.2-fold (0.09 log units) below the measured number, within the range that was stated.
By their numbers in the histone-lysine N-methyltransferase EZH2 assay, from the lowest: compounds 1, 3 and 2 (each within the scatter of the next, the first and the last beyond it).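

In the histone-lysine N-methyltransferase EZH2 assay the oxygen substituent change gives a 1.5-fold lower number from compound 2 to compound 3 (0.16 log units; within the scatter), and hydrogen in place of methyl on an aromatic carbon gives a 1.8-fold higher number from compound 1 to compound 3 (0.26 log units; within the scatter). In a physicochemical assay for solubility, measured as kinetic solubility (on this read-out higher numbers stand for higher solubility and lower numbers for lower solubility), compound 2 gives 19600 nM and compound 3 gives 510000 nM. At this position, then, oxolan-3-yl in place of isopropyl leaves inhibition within the scatter while solubility moves well beyond it: the measured solubility of compound 2, 19600 nM, and of compound 3, 510000 nM, a 26-fold higher number (1.42 log units; beyond the scatter)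

From the compounds shown here alone, whether the opposite stereocentre of the oxolan-3-yl group would behave alike remains open. So does whether an amine or a longer ether chain on this oxygen would keep inhibition while matching this solubility.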